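The source may report more compounds than this note shows. Statements on the series, on what has been measured and on what is new or still open speak of the compounds shown alone.

In an assay on isolated protein for activation of cGMP-dependent protein kinase 1 (Homo sapiens), read by ADP-Glo, with stated times of 120 min and 40 min (on this read-out higher numbers stand for an effect only at larger amounts of compound and lower numbers for an effect already at smaller amounts), compound 1 (`COc1cc(C(=O)O)ccc1CN1CCC[C@H](OCc2cc(Cl)cc(Cl)c2)[C@@H]1c1ccccc1`) gives 62000 nM. Of the two compounds measured, this is the highest number, so on this read-out the effect of compound 1 appears only at the larger amount of compound. Compound 2 (`OC[C@@H](O[C@H]1CCCN(Cc2ccccc2Cc2nnco2)[C@H]1c1ccccc1)c1cc(Cl)cc(Cl)c1`) gives 3700 nM in this assay, a lower number, and the gap between the two lies beyond the usual scatter of such measurements. The two structures differ in several places at once, so no single change can be read from this pair.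

Compound 3 (`O=C(O)c1ccc(CN2CCC[C@H](OCc3cc(Cl)cc(Cl)c3)[C@@H]2c2ccccc2)cc1`) has not yet been measured in this assay. It differs from compound 1 in one place: hydrogen in place of methoxy on an aromatic carbon. Among the compounds with values here, no measured pair shows this change on its own, and nothing in the two numbers points in a direction, so the step of a 1.1-fold lower number from compound 1 to compound 3 (0.05 log units; within the scatter) that the estimate means is expected to stay within the scatter. Compound 3 is therefore expected to give about 55000 nM in this assay, within a range from 20000 nM to 150000 nM.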

Compound 3, half-maximal effective concentration: 76000 nM
Compound 3: the middle estimate sits 1.4-fold (0.14 log units) below what was measured, within the range that was stated.
By their numbers in this assay, from the lowest: compound 2; then compounds 1 and 3 (each within the scatter of the next).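

In this assay the methoxy on the aromatic carbon ortho to a large group and meta to a carboxy group can be replaced by hydrogen, which gives a 1.2-fold higher number from compound 1 to compound 3 (0.09 log units; within the scatter) and leaves the two compounds indistinguishable on this read-out. Within the data shown here, this is the first direct reading of this position, and in this single pair, removing one carbon and one oxygen leaves no difference beyond the usual scatter. The information at hand offers no explanation for this result.

Hydrogen and methoxy are the only two groups shown at this place, so it remains open whether a fluorine, an amine or a longer ether chain there would shift the number. Also open, on these data alone, is whether replacing the carboxylic acid of compound 3 with an amide or a tetrazole would change the reading, and whether hydrogen and methoxy would still match on a different core.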